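Benzyl variation on the shared nucleoside core: outlook for compound 4

This account rests on a few compounds, and the source may have more. Where it says the series, first, only, none or still open, it means among the compounds named here.

Three members of the series have been run in a functional assay on CCRF-CEM cells (Homo sapiens) for antiproliferative activity, with a stated time of 72 h; on this read-out higher numbers stand for weaker inhibition and lower numbers for stronger inhibition. Compound 1 `OC[C@H]1O[C@@H](n2cnc3c(NCc4cccc(F)c4)ncnc32)[C@H](O)[C@@H]1O` carries 3-fluorophenyl on a saturated chain carbon bound to a nitrogen on an aromatic ring, and in this assay compound 1 gives 4000 nM. Compound 2 `OC[C@H]1O[C@@H](n2cnc3c(NCc4ccc(Cl)cc4Cl)ncnc32)[C@H](O)[C@@H]1O` carries 2,4-dichlorophenyl at that place; in this assay compound 2 gives 86700 nM, a step of a 22-fold higher number from compound 1 to compound 2 (1.34 log units; beyond the scatter). Compound 3 `COc1cc(CNc2ncnc3c2ncn3[C@@H]2O[C@H](CO)[C@@H](O)[C@H]2O)cc(OC)c1`, with 3,5-dimethoxyphenyl, reaches only a limit of the assay, and in this assay compound 3 gives > 166000 nM. The step to it is an at least 41-fold higher number from compound 1 to compound 3 (1.61 log units; beyond the scatter), and also an at least 1.9-fold higher number from compound 2 to compound 3 (0.28 log units; that floor lies within the scatter); what is known of compound 3 is only (the limit of > 166000 nM in this assay, at which 1 of the 3 values shown sits).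

Compound 4 `Cc1ccc(O)c(CNc2ncnc3c2ncn3[C@@H]2O[C@H](CO)[C@@H](O)[C@H]2O)c1` differs from compound 3 by 2-hydroxy-5-methylphenyl in place of 3,5-dimethoxyphenyl on a saturated chain carbon bound to a nitrogen on an aromatic ring. Among the measured compounds shown here, the steps that bear on this are those into compound 3 from compound 1 and compound 2, both of which moved toward weaker inhibition as the phenyl substituents changed. As far as these compounds go, since compound 3 sits at the limit, its true distance from compound 1 is unknown, so the size of any return cannot be read from the data. In this assay compound 4 is expected at 60000 nM, within 10000 nM to 200000 nM. The step expected is an at least 2.7-fold lower number from compound 3 to compound 4 (0.44 log units; beyond the scatter), toward stronger inhibition, with the outcome possibly again a limit.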

Compound 4, half-maximal inhibitory concentration: 1900 nM
Compound 4: the middle estimate sits 32-fold (1.50 log units) above what was measured, and the stated range ends above it.
By their numbers in this assay, from the lowest: compound 4; then compound 1; then compound 2. At a limit, above all of these: compound 3.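

In this assay every earlier change away from 3-fluorophenyl on this saturated chain carbon gave weaker inhibition, whereas 2-hydroxy-5-methylphenyl goes the other way (with a 2.1-fold lower number from compound 1 to compound 4 (0.32 log units; beyond the scatter)) and makes compound 4 the strongest inhibitor of the four. Two substituents on the phenyl ring therefore do not by themselves mean weak inhibition here, since the other two disubstituted phenyl groups sit far higher (the change gives a 46-fold lower number from compound 2 to compound 4 (1.66 log units; beyond the scatter) and an at least 87-fold lower number from compound 3 to compound 4 (1.94 log units; beyond the scatter)). Compound 3 stands at a limit and not at a number, so the second of these steps is only a floor: the limit of > 166000 nM in this assay, at which 1 of the 4 values shown sits.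

Both the hydroxyl and the methyl enter in one change, so the compounds shown leave open which of them, or whether the pair together, carries the gain over 2,4-dichlorophenyl and 3,5-dimethoxyphenyl. Also open, as far as these compounds go, is how an amine or a carboxylic acid on the phenyl ring would read in this assay on the shared core.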